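Replacing bromo with methoxy in compound 3

The compounds below may be only part of what the source reports. "The series", "measured", "known", "first", "only" and "open" are said of these compounds alone.

In an ADME assay on HepG2 cells (Homo sapiens) for cytotoxicity, read by MTT assay, with a stated time of 72 h (on this read-out higher numbers stand for lower toxicity in this test and lower numbers for higher toxicity in this test), compound 1 `CC(C)Nc1nc2ccsc2c(=O)[nH]1` gives 23900 nM. Compound 2 `CC(C)Nc1nc2c(-c3ccc(F)cc3)csc2c(=O)[nH]1` gives > 15600 nM, which is a limit of the assay and not a number. Compound 3 `CC(C)Nc1nc2c(-c3ccc(Br)cc3)csc2c(=O)[nH]1` gives 6500 nM, the lower of the two actual numbers in the series.

The next change leads to compound 4 `COc1ccc(-c2csc3c(=O)[nH]c(NC(C)C)nc23)cc1`: methoxy in place of bromo on an aromatic carbon, para to a large group (methoxy in place of bromo on an aromatic carbon). Going by the values given here, no compound with methoxy has been measured, so the evidence is indirect. The 4-bromophenyl group in place of hydrogen gives a 3.7-fold lower number from compound 1 to compound 3 (0.57 log units; beyond the scatter), while the 4-fluorophenyl group in place of hydrogen gives a step that the limit leaves unreadable from compound 1 to compound 2. Among the compounds with values here, the closest precedent is the exchange of one group for another on the same ring, which gives an at least 2.4-fold lower number from compound 2 to compound 3 (0.38 log units; beyond the scatter). Taking that step as the guide, the loss of bromo is expected to bring a modestly higher number in this assay, although a change within the scatter remains possible. The expected step is a 2.2-fold higher number from compound 3 to compound 4 (0.33 log units; beyond the scatter). For compound 4 the estimated value is 14000 nM, with an expected range of 6000 nM to 33000 nM.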

Compound 4, half-maximal cytotoxic concentration: 27800 nM
The estimate for compound 4 lay 2.0-fold (0.30 log units) below the measured number, within the range that was stated.
By their numbers in this assay, from the lowest: compound 3; then compounds 1 and 4 (each within the scatter of the next).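

In this assay, methoxy in place of bromo on an aromatic carbon, para to a large group, gives a 4.3-fold higher number from compound 3 to compound 4 (0.63 log units; beyond the scatter), so this position now has an exchange of one group for another read between two actual numbers. Compound 1 gives 23900 nM and compound 4 gives 27800 nM, two values within the scatter of each other, so a substituted phenyl group at this place does not by itself go with a lower number, and among the actual numbers only compound 3 stands apart. Compound 2 gives > 15600 nM, which is a limit and not a number, and the steps to it from compound 1 and from it to compound 4 cannot be read: the limit of > 15600 nM in this assay, at which 1 of the 4 values shown sits.

The compounds shown leave open whether chloro, an amine or a carboxylic acid on this aromatic carbon would fall with compound 3 or with compound 4, and whether a longer chain such as ethoxy would stay with compound 4. Going by these compounds alone, the lower number also rests on the single bromo compound, compound 3, so its link to bromo is still tied to one example.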